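This account rests on a few compounds, and the source may have more. Where it says the series, first, only, none or still open, it means among the compounds named here.

Compound 1, `Cc1cc(C(C)C)ccc1OC(c1ccc(Cl)cc1)c1cnc(NC(=O)OC(C)(C)C)s1`: in an ADME assay on HepG2 2.2.15 cells (Homo sapiens) for cytotoxicity (a lower number here means that less compound is tolerated, a higher number that more compound is tolerated), compound 1 gives > 50000 nM, which is a limit of the assay rather than a number.
Compound 2, `CC(C)(C)OC(=O)Nc1ncc(C(Oc2ccc(F)c(Cl)c2)c2ccc(Cl)cc2)s1`: in this assay compound 2 gives > 50000 nM, again a limit of the assay.

Within the data shown here, compound 2 therefore stands at the top of what this assay can report, and so does the only other measured compound: the limit of > 50000 nM in this assay, at which 2 of the 2 values shown sit. Among the measured compounds shown here, the one measured step, a step that the two limits leave unreadable from compound 1 to compound 2, cannot be read for size, because both of its ends are limits.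

Compound 3, `CC(C)(C)OC(=O)Nc1ncc(C(Oc2cccc(C#N)c2)c2ccc(Cl)cc2)s1`, differs from compound 2 in one place: 3-cyanophenyl in place of 3-chloro-4-fluorophenyl on an oxygen on a saturated carbon. For the measured compounds named here, no measured step bears on this change with a readable size, so the expectation rests only on the fact that both measured compounds sit at the limit. The step of a number no higher from compound 2 to compound 3 (the limit leaves the size open) is estimated to be none beyond the scatter. Compound 3 is accordingly expected to give about 50000 nM in this assay, with a range from 20000 nM to 100000 nM, and most likely to be reported again only as a limit.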

Compound 3, half-maximal cytotoxic concentration: > 50000 nM
Compound 3 ended at the assay's limit; the forecaster's own chance of this, stated with the estimate: 80%; the middle value lies on the limit itself.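

In this assay compound 3 gives > 50000 nM and this too is a limit rather than a number. Among these compounds, no step among compound 1, compound 2 and compound 3 can be read for size: the limit of > 50000 nM in this assay, at which 3 of the 3 values shown sit. The compounds shown leave open how much compound each one really tolerates, and whether changing the group on the oxygen matters at all.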